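The source may hold more compounds than are shown below. What is called first, only, known or untested is meant among the compounds shown, and "the series" means these compounds.

Compound 3 `COc1ccc(-c2cn(-c3cccc(C(=O)/C=C/c4cc(OC)c(OC)c(OC)c4)c3)c(=O)[nH]2)cc1` and compound 2 `COc1ccc(-c2cn(-c3cccc(C(=O)/C=C/c4ccc(O)c(OC)c4)c3)c(=O)[nH]2)cc1` share one core and differ only at the chain end: 4-hydroxy-3-methoxyphenyl in place of 3,4,5-trimethoxyphenyl on a double-bonded chain carbon bound to a double-bonded chain carbon. In a functional assay on OVCAR-4 cells (Homo sapiens) for inhibition (a higher number here means a weaker inhibitor of growth, a lower number a stronger inhibitor of growth), compound 3 gives 3570 nM, while compound 2 gives 6080 nM; the step of a 1.7-fold lower number from compound 2 to compound 3 (0.23 log units; within the scatter) stays within the scatter, so the two cannot be ranked. Compound 1 `COc1cc(/C=C/C(=O)c2cccc(-n3cc(-c4ccc(Cl)cc4)[nH]c3=O)c2)cc(OC)c1OC` is compound 3 with one swap, (chloro in place of methoxy on an aromatic carbon), and in this assay compound 1 gives 11400 nM, so a 3.2-fold higher number from compound 3 to compound 1 (0.50 log units; beyond the scatter). Compound 4 `COc1cc(/C=C/C(=O)c2cccc(-n3cc(-c4ccc(Cl)cc4)[nH]c3=O)c2)ccc1O` carries the same change made on compound 2, (chloro in place of methoxy on an aromatic carbon), at a place described in the same words. Among the compounds with values here, a step of about a 3.1-fold higher number from compound 2 to compound 4 (0.49 log units; beyond the scatter) is expected in this assay for compound 4, resting on the earlier step because a 3.2-fold higher number from compound 3 to compound 1 (0.50 log units; beyond the scatter) is the only example of this swap seen here. Compound 4 is estimated at 19000 nM, with a range from 8000 nM to 45000 nM.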

Compound 4, concentration for 50% growth inhibition: 4640 nM
For compound 4 the middle estimate is 4.1-fold (0.61 log units) above the measured one; the whole stated range lies above it.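

In this assay, replacing 4-methoxyphenyl with 4-chlorophenyl gives a 1.3-fold lower number from compound 2 to compound 4 (0.12 log units; within the scatter), so compound 2 and compound 4 cannot be ranked. The same change therefore does not carry over with the same size from one core to the other: the same change on two cores in this assay, a 3.2-fold higher number (0.50 log units; beyond the scatter) from compound 3 to compound 1 and a 1.3-fold lower number (0.12 log units; within the scatter) from compound 2 to compound 4, 4.2-fold (0.62 log units) apart, beyond the scatter of two such steps. The two cores differ only in 3,4,5-trimethoxyphenyl against 4-hydroxy-3-methoxyphenyl, but two pairs cannot show why the change behaves differently on them, or which result is more typical of the series.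

The compounds shown leave open how a fluoro or a dimethylamino group at the same place would behave on each core.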